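Replacing the 2-carboxypropyl Group of Compound 1

This account rests on a few compounds, and the source may have more. Where it says the series, first, only, none or still open, it means among the compounds named here.

Going by the values given here, in a physicochemical assay for lipophilicity, read by HPLC, at pH 7.5 (on this read-out higher numbers stand for higher lipophilicity and lower numbers for lower lipophilicity), compound 1 (`CCOc1ccccc1-c1ccc(-c2nc3cnccc3c(C[C@H](C)C(=O)O)c2C#N)cc1`) gives 2.2, the lower of the two numbers so far. Compound 2 (`CC[C@@H](Nc1c(C#N)c(-c2ccc(-c3ccccc3N(C)C)cc2)nc2cnccc12)C(N)=O`) gives 3.2, higher by more than the usual scatter. Compound 3 (`CCOc1ccccc1-c1ccc(-c2nc3cnccc3c(NC(C(N)=O)C3CC3)c2C#N)cc1`) differs from compound 1 in one place: a group of 8 heavy atoms (5 carbon, 2 nitrogen, 1 oxygen; one three-membered non-aromatic ring of carbon only) in place of a group of 6 heavy atoms (4 carbon, 2 oxygen; no ring), on an aromatic carbon. The change sits on an aromatic carbon, ortho to a cyano group. The entering group looks more like the side chain of compound 2, at 3.2, than the group it replaces, so a rise beyond the scatter is expected in this assay. The expected step is a number 0.90 log units higher from compound 1 to compound 3 (beyond the scatter). For compound 3 the estimate is 3.1, within a range of 2.6 to 3.6.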

Compound 3, distribution coefficient: 3
Estimate against measurement, compound 3: 0.10 log units above, and the stated range covers the measured number.
By their numbers in this assay, from the lowest: compound 1; then compounds 3 and 2 (each within the scatter of the next).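

In this assay, the group with the three-membered carbon ring, in place of the 2-carboxypropyl group, gives a number 0.80 log units higher from compound 1 to compound 3 (beyond the scatter). This shows that a single change on this aromatic carbon, ortho to a cyano group, can shift the read-out beyond the scatter. Nothing measured here bears on the reason for the step. The entering group differs from the old one in its ring, its size and its atoms together, so the compounds shown do not separate these parts. Going by these compounds, how a simple amine or a longer carbon chain would read at this position remains open.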